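This account rests on a few compounds, and the source may have more. Where it says the series, first, only, none or still open, it means among the compounds named here.

Series notes. In a functional assay for agonist activity at 5-hydroxytryptamine receptor 4 (Homo sapiens), read by cAMP accumulation (a lower number here means that less compound is needed, a higher number that more compound is needed for the effect), compound 2 `CC(C)c1nc2c(C(=O)NCC3CCN(CCN4CCN(S(C)(=O)=O)CC4)CC3)cccc2[nH]1` gives 0.794 nM; compound 1 `CS(=O)(=O)N1CCN(CC(O)CN2CCC(CNC(=O)c3cccc4[nH]c(C5CC5)nc34)CC2)CC1` gives 0.631 nM, and these two numbers lie within the usual scatter of each other, so no order between them is read. Compound 3 `CC(=O)N1CCC(CN2CCC(CNC(=O)c3cccc4[nH]c(C(C)C)nc34)CC2)CC1` carries 1-acetylpiperidin-4-yl in place of (4-(methylsulfonyl)piperazin-1-yl)methyl on a saturated chain carbon bound to an amine nitrogen in a ring. Among the measured compounds shown here, no measured pair isolates this change; the expected step is a 1.9-fold higher number from compound 2 to compound 3 (0.28 log units; within the scatter), small and if anything towards a higher number, since both measured compounds sit close together at the low end. Compound 3 is accordingly estimated in this assay at 1.5 nM, between 0.4 nM and 6 nM.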

Compound 3, half-maximal effective concentration: 1.59 nM
The estimate for compound 3 lay 1.1-fold (0.03 log units) below the measured number, and the stated range covers the measured number.
By their numbers in this assay, from the lowest: compounds 1, 2 and 3 (each within the scatter of the next, the first and the last beyond it).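

In this assay, 1-acetylpiperidin-4-yl in place of (4-(methylsulfonyl)piperazin-1-yl)methyl on a saturated chain carbon bound to an amine nitrogen in a ring gives a 2.0-fold higher number from compound 2 to compound 3 (0.30 log units; within the scatter), so this place accepts a ring without the sulfonyl group or second ring nitrogen with no readable change. Nothing at hand bears on the reason for this result. Still open, as far as these compounds go, is whether a carboxylic acid or a primary amine at this place would hold the number. Also open, from the compounds shown here alone, is what a methylsulfonyl group on the piperidine nitrogen of compound 3 would do.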